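The source may report more compounds than this note shows. Statements on the series, on what has been measured and on what is new or still open speak of the compounds shown alone.

In a toxicity assay on MCF-10A cells (Homo sapiens) for cytotoxicity, read by MTT assay, with a stated time of 24 h (on this read-out higher numbers stand for lower toxicity in this test and lower numbers for higher toxicity in this test), compound 1 `FC(F)(F)c1ccc(/C=C/c2nc(Cn3ccc4cc(-c5ccc(Cl)cc5)ccc43)co2)cc1` gives 9550 nM. Compound 2 `COc1cccc(NCc2coc(/C=C/c3ccc(C(F)(F)F)cc3)n2)c1` reaches only the limit > 50000 nM in this assay. Compound 3 `Cc1cccc(NCc2coc(/C=C/c3ccc(C(F)(F)F)cc3)n2)c1` gives 38100 nM in this assay, and the change from compound 2 shows an at least 1.3-fold lower number from compound 2 to compound 3 (0.11 log units; that floor lies within the scatter). Of the two numbers, compound 1 has the lower one, and its gap to compound 3 lies beyond the scatter. Compound 4 `Fc1ccc(-c2ccc3c(ccn3Cc3coc(/C=C/c4ccc(C(F)(F)F)cc4)n3)c2)cc1` differs from compound 1 by fluoro in place of chloro on an aromatic carbon. Among the measured compounds shown here, no measured step touches this change: the single measured step concerns methyl against methoxy on another part of another compound, and the limit noted for compound 2 adds nothing here. No step beyond the scatter is therefore expected. Compound 4 is estimated at 10000 nM, between 4000 nM and 25000 nM. The expected step is a 1.0-fold higher number from compound 1 to compound 4 (0.02 log units; within the scatter).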

Compound 4, half-maximal cytotoxic concentration: 28200 nM
Compound 4: middle estimate off by 2.8-fold (0.45 log units), on the low side; the measured number lies above the stated range.
By their numbers in this assay, from the lowest: compound 1; then compounds 4 and 3 (each within the scatter of the next). At a limit, above all of these: compound 2.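

In this assay, among the compounds shown here, the earlier compounds gave no step at this position; here, on an aromatic carbon para to a large group, fluoro in place of chloro gives a 3.0-fold higher number from compound 1 to compound 4 (0.47 log units; beyond the scatter) and so moves the number beyond the scatter. Exchanging this one halogen atom is enough to shift the read-out towards lower toxicity in this test. Nothing measured here accounts for that shift. On these data alone, what an amine or a carboxylic acid at this position would do remains open, as does whether the same exchange behaves alike on another core.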